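The source may report more compounds than this note shows. Statements on the series, on what has been measured and on what is new or still open speak of the compounds shown alone.

In an ADME assay on microsomes from liver (Homo sapiens) for metabolic stability (a higher number here means faster removal of the compound, a lower number slower removal), compound 2 `COc1cc(OC)c(F)c(COc2cnc(Nc3ccc(N4CCC(N5CCN(C)CC5)CC4)c(C)c3)nc2)c1F` gives 58 mL/min/kg and compound 1 `COc1cc(Nc2ncc(OCc3c(F)c(OC)cc(OC)c3F)cn2)ccc1N1CCN(C)CC1` gives 39 mL/min/kg, so the two sit within the usual scatter of each other. Compound 3 `COc1cc(Nc2ncc(OCc3c(F)c(OC)cc(OC)c3F)cn2)ccc1N1CCC(N2CCN(C)CC2)CC1` keeps compound 2 unchanged except at one place, with methoxy in place of methyl on an aromatic carbon. Among the compounds with values here, no pair of measured compounds differs at only one place, which leaves no direct guide to the size of this change. The expected step, a 1.2-fold lower number from compound 2 to compound 3 (0.06 log units; within the scatter), is therefore small and not beyond the scatter in either direction. Compound 3 is estimated at 50 mL/min/kg, with an expected range of 28 mL/min/kg to 85 mL/min/kg.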

Compound 3, clearance in the Homo sapiens assay: 40 mL/min/kg
For compound 3 the middle estimate is 1.3-fold (0.10 log units) above the measured one; the range from low to high includes it.
By their numbers in the Homo sapiens assay, from the lowest: compounds 1, 3 and 2 (each within the scatter of the next).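

Within the data shown here, in the Homo sapiens assay, methoxy in place of methyl on this aromatic carbon, ortho to a large group, gives a 1.5-fold lower number from compound 2 to compound 3 (0.16 log units; within the scatter), the first step here that isolates a single place. The same change therefore has no effect on clearance that can be told from the scatter, yet in a physicochemical assay for lipophilicity, read by LC-MS, in phosphate buffer, measured as octanol-water partition, at pH 7.4 (on this read-out lower numbers stand for lower lipophilicity and higher numbers for higher lipophilicity), it does show beyond the scatter: the measured distribution coefficient of compound 2, 4.1, and of compound 3, 3.3, a number 0.80 log units lower (beyond the scatter)

In the physicochemical assay compound 2 gives 4.1 and compound 3 gives 3.3 as measured values.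

Going by these compounds, whether a chlorine atom or an ethoxy group at this position would shift either read-out further remains open. So does whether methoxy in place of methyl behaves the same way with other groups elsewhere on the shared core.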